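From 4-fluorophenyl to pyridin-3-yl on compound 1

This account rests on a few compounds, and the source may have more. Where it says the series, first, only, none or still open, it means among the compounds named here.

For the measured compounds named here, in a functional assay on MDA-MB-231 cells (Homo sapiens) for antiproliferative activity, with a stated time of 4 days (a higher number here means a weaker inhibitor, a lower number a stronger inhibitor), compound 1 `CCCCc1ccc2[nH]c(-c3ccc(OC)cc3)c(/C=N/NC(=O)c3ccc(F)cc3)c2c1` gives 19 nM, the lowest of three numbers so far. Compound 3 `CCCCc1ccc2[nH]c(-c3ccc(C(F)(F)F)cc3)c(/C=N/NC(=O)c3ccncc3)c2c1` gives 94 nM and compound 2 `CCCCc1ccc2[nH]c(-c3ccc(C(F)(F)F)cc3)c(/C=N/NC(=O)c3ccc([N+](=O)[O-])cc3)c2c1` gives 2040 nM. Compound 4 `CCCCc1ccc2[nH]c(-c3ccc(OC)cc3)c(/C=N/NC(=O)c3cccnc3)c2c1` carries pyridin-3-yl in place of 4-fluorophenyl on a carbonyl carbon. Going by the values given here, only one measured step bears on this, and only indirectly: a 22-fold lower number from compound 2 to compound 3 (1.34 log units; beyond the scatter), a large step, but one with pyridin-4-yl replacing 4-nitrophenyl. Among the compounds with values here, compound 3, the only measured compound with a pyridine ring, gives 94 nM, though it also differs from compound 1 elsewhere. A moderate rise beyond the scatter is therefore expected. The estimated step is a 3.2-fold higher number from compound 1 to compound 4 (0.50 log units; beyond the scatter). For compound 4 the expected value is 60 nM, within an estimated range of 15 nM to 250 nM.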

Compound 4, half-maximal inhibitory concentration: 35 nM
Estimate against measurement, compound 4: 1.7-fold (0.23 log units) above; the range from low to high includes it.
By their numbers in this assay, from the lowest: compounds 1 and 4 (each within the scatter of the next); then compound 3; then compound 2.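

In this assay, pyridin-3-yl in place of 4-fluorophenyl on a carbonyl carbon gives a 1.8-fold higher number from compound 1 to compound 4 (0.27 log units; within the scatter), so the two compounds cannot be told apart. For the compounds shown here, this is the first step at this position on the core of compound 1, and it shows that a ring carrying a hydrogen-bond acceptor can stand here without a change beyond the scatter. No measurement bears on why the two rings read alike.

On these data alone, whether an amine or a carboxylic acid on the ring at this carbonyl carbon would hold the number stays open. Going by these compounds alone, also open is how pyridin-4-yl, seen only on compound 3 and compared only with 4-nitrophenyl, reads on the core of compound 1.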